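The compounds below may be only part of what the source reports. "The series", "measured", "known", "first", "only" and "open" are said of these compounds alone.

Compound 1 `O=c1[nH]cnc2c1c(-c1ccoc1)cn2[C@@H]1O[C@H](CO)[C@@H](O)[C@H]1O` and compound 2 `O=c1[nH]cnc2c1c(-c1cccs1)cn2[C@@H]1O[C@H](CO)[C@@H](O)[C@H]1O` share one core and differ at a single group. In a functional assay on HCT-116 cells (Homo sapiens), read by MTT assay, with a stated time of 72 h (on this read-out higher numbers stand for weaker inhibition and lower numbers for stronger inhibition), compound 1 gives 14800 nM. For compound 2 the result is reported only as a limit, > 20000 nM. The change furan-3-yl in place of thiophen-2-yl on an aromatic carbon thus made a step of an at least 1.3-fold lower number from compound 2 to compound 1 (0.13 log units; that floor lies within the scatter). Compound 3 `Nc1nc(N)c2c(-c3cccs3)cn([C@@H]3O[C@H](CO)[C@@H](O)[C@H]3O)c2n1` carries the thiophen-2-yl group on a second core; the difference between the two cores is not broken down here. For compound 3 the result is again only a limit, > 20000 nM, which is the limit of > 20000 nM in this assay, at which 2 of the 3 values shown sit. Compound 4 `Nc1nc(N)c2c(-c3ccoc3)cn([C@@H]3O[C@H](CO)[C@@H](O)[C@H]3O)c2n1` is its unmeasured counterpart, obtained by the same change, (furan-3-yl in place of thiophen-2-yl on an aromatic carbon). Because the same change gave an at least 1.3-fold lower number from compound 2 to compound 1 (0.13 log units; that floor lies within the scatter), the step from compound 3 to compound 4 is estimated as a step that the limit leaves unreadable from compound 3 to compound 4. Compound 4 is therefore expected to give about 25000 nM, probably again as a limit, somewhere from 8000 nM to 80000 nM.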

Compound 4, half-maximal inhibitory concentration: > 20000 nM
Compound 4 ended at the assay's limit (the forecaster's own chance of this, stated with the estimate: 70%); the middle value is on the limit's open side.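

Compound 3 and compound 4 both end only as limits, so no step between them can be read: the limit of > 20000 nM in this assay, at which 3 of the 4 values shown sit.

Going by these compounds, whether furan-3-yl in place of thiophen-2-yl changes the number at all on this core stays open.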